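Thiophen-3-yl to 3-hydroxyphenyl on the shared chain

The source may report more compounds than this note shows. Statements on the series, on what has been measured and on what is new or still open speak of the compounds shown alone.

Measured so far in a functional assay on MCF7 cells (Homo sapiens) for cytotoxicity; on this read-out higher numbers stand for weaker inhibition and lower numbers for stronger inhibition:
- compound 1 `C=C/C=C\[C@H](C)[C@H](OC(N)=O)[C@@H](C)[C@H](O)[C@@H](C)C/C(C)=C\[C@H](C)[C@@H](O)[C@@H](C)/C=C\CCc1cccc(F)c1` gives 370 nM
- compound 2 `C=C/C=C\[C@H](C)[C@H](OC(N)=O)[C@@H](C)[C@H](O)[C@@H](C)C/C(C)=C\[C@H](C)[C@@H](O)[C@@H](C)/C=C\CCc1cccc(Cl)c1` gives 400 nM
- compound 3 `C=C/C=C\[C@H](C)[C@H](OC(N)=O)[C@@H](C)[C@H](O)[C@@H](C)C/C(C)=C\[C@H](C)[C@@H](O)[C@@H](C)/C=C\CCc1ccsc1` gives 850 nM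

Compound 3 has the highest number of the three, and both of its steps to the others lie beyond the scatter, so it is the weakest inhibitor of this set. The next compound, compound 4 `C=C/C=C\[C@H](C)[C@H](OC(N)=O)[C@@H](C)[C@H](O)[C@@H](C)C/C(C)=C\[C@H](C)[C@@H](O)[C@@H](C)/C=C\CCc1cccc(O)c1`, differs from it at one place: 3-hydroxyphenyl in place of thiophen-3-yl on a saturated chain carbon, two bonds along the chain from a double-bonded chain carbon. In words, 3-hydroxyphenyl stands in place of thiophen-3-yl on a saturated chain carbon, two bonds along the chain from a double-bonded chain carbon.

Going by the values given here, two measured steps bear on this change. Both run at the same place but lead towards the thiophen-3-yl compound: a 2.3-fold higher number from compound 1 to compound 3 (0.36 log units; beyond the scatter) and a 2.1-fold higher number from compound 2 to compound 3 (0.33 log units; beyond the scatter). Both are modest. Trading the halogens gave a 1.1-fold higher number from compound 1 to compound 2 (0.03 log units; within the scatter) and so separates nothing. Among the compounds with values here, no compound with a hydroxyl group has been measured, so this comparison carries only partly over to compound 4. A modest move towards a lower number is therefore expected, with the expected step being a 1.8-fold lower number from compound 3 to compound 4 (0.25 log units; within the scatter) in this assay and possibly no larger than the scatter. Compound 4 is estimated at 480 nM with an expected range from 170 nM to 1300 nM in this assay.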

Compound 4, half-maximal inhibitory concentration: 130 nM
Compound 4: middle estimate off by 3.7-fold (0.57 log units), on the high side; the measured number lies below the stated range.
By their numbers in this assay, from the lowest: compound 4; then compounds 1 and 2 (each within the scatter of the next); then compound 3.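

In this assay, going by these compounds alone, the place that had so far only separated thiophen-3-yl from the halogenated rings proves able to shift the number much further, as 3-hydroxyphenyl brings a larger step than any seen there before (a 6.5-fold lower number from compound 3 to compound 4 (0.82 log units; beyond the scatter)) and makes compound 4 the strongest inhibitor of the four. The aromatic carbon where trading fluoro for chloro had separated nothing also turns out to matter, with hydroxy lowering the number against both chloro (a 3.1-fold lower number from compound 2 to compound 4 (0.49 log units; beyond the scatter)) and fluoro (a 2.8-fold lower number from compound 1 to compound 4 (0.45 log units; beyond the scatter)), so the identity of the group on that carbon does count once it is not a halogen. Nothing available here accounts for why the hydroxy compound stands lowest in this series.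

The compounds shown leave open whether the hydroxyl itself is needed or whether a methoxy group, an amine or a carboxylic acid on that same aromatic carbon would do as well. They also leave open how the 2-(3-hydroxyphenyl)ethyl group compares with 3-hydroxybenzyl or a longer chain carrying the same ring.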